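Replacing a thiophene by a carboxyphenyl on the shared core

The compounds below may be only part of what the source reports. "The series", "measured", "known", "first", "only" and "open" are said of these compounds alone.

Measured compounds:
compound 1 `Cc1ccccc1-n1nc(C)c2c1NC(=O)[C@H](C)S[C@@H]2c1ccc(-c2ccoc2)cc1` — 3500 nM
compound 2 `Cc1ccccc1-n1nc(C)c2c1NC(=O)[C@H](C)S[C@@H]2c1ccc(-c2ccsc2)cc1` — 1400 nM

In an assay on isolated protein for agonist activity at Bile acid receptor (Homo sapiens), read by AlphaScreen, with a stated time of 30 min (on this read-out lower numbers stand for an effect already at smaller amounts and higher numbers for an effect only at larger amounts of compound), compound 2 gives the lowest of the two numbers; its nearest neighbour is compound 1, and the step of a 2.5-fold lower number from compound 1 to compound 2 (0.40 log units; beyond the scatter) lies beyond the scatter, so compound 2 stands apart as the lower of the pair. Compound 3 `Cc1ccccc1-n1nc(C)c2c1NC(=O)[C@H](C)S[C@@H]2c1ccc(-c2cccc(C(=O)O)c2)cc1` is not yet measured. It differs from compound 2 by one change: 3-carboxyphenyl in place of thiophen-3-yl on an aromatic carbon. Among the compounds with values here, the only measured step, from compound 1 to compound 2, exchanges one five-membered heteroaromatic ring for another and was modest; it does not directly cover the entry of a 3-carboxyphenyl, so the expectation rests on a thin basis. The estimate for compound 3 is therefore centred near compound 2, with a wide range on both sides, and the step of a 1.4-fold higher number from compound 2 to compound 3 (0.15 log units; within the scatter) is expected to be small relative to that uncertainty. Compound 3 is estimated at 2000 nM, within 300 nM to 15000 nM.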

Compound 3, half-maximal effective concentration: "not active" (no number reported)
Compound 3 has no reported number here; there is nothing to compare the estimate with.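

Within the data shown here, compound 3 is reported as "not active" without a number, so no step from compound 2 to compound 3 can be read. Nothing shown here explains this result. The compounds shown leave open how large the effect of the 3-carboxyphenyl change is.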